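Thioether replaced by an amide on the shared core

A few compounds are considered here, and "the series" means these few. Any claim that something is new, unique, unknown or untested is made for them only; others in the source may bear on it.

Measured compounds:
Compound 2 `CC(C)Cn1c(=O)n(C)c(=O)c2nc(SCCCCO)c(Cc3cccc4ccccc34)nc21`: 37 nM
Compound 1 `CC(C)Cn1c(=O)n(C)c(=O)c2c1nc(Cc1cccc3ccccc13)c(=O)n2CCCCO`: 150 nM

In a functional assay on Raji cells (Homo sapiens) for inhibition, read by MTT assay, with a stated time of 96 h (on this read-out lower numbers stand for an effect already at smaller amounts and higher numbers for an effect only at larger amounts of compound), compound 2 gives 37 nM, the lowest of the two numbers at hand. Its nearest neighbour is compound 1, which gives 150 nM, a gap that lies beyond the scatter; the two compounds differ in more than one place, so the values are shown side by side without a counted step.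

Compound 3 `CC(C)Cn1c(=O)n(C)c(=O)c2nc(C(=O)NCCCO)c(Cc3cccc4ccccc34)nc21` is not yet measured. It differs from compound 2 by (3-hydroxypropyl)carbamoyl in place of (4-hydroxybutyl)sulfanyl on an aromatic carbon. For the measured compounds named here, no step between measured compounds involves a change of this kind, so the expectation for compound 3 rests on compound 2 alone, with wide uncertainty. The change from compound 2 to compound 3 is expected to move the number upward by a 2.4-fold higher number from compound 2 to compound 3 (0.39 log units; beyond the scatter), likely at the edge of the scatter. For compound 3 the estimate is 90 nM, within a range from 25 nM to 400 nM.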

Compound 3, half-maximal effective concentration: > 10000 nM
Compound 3: no number, only a limit; the forecaster's own chance of this, stated with the estimate: 5%; at least 110-fold (2.04 log units) between middle value and limit.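

At the aromatic carbon ortho to the (naphthalen-1-yl)methyl group, (3-hydroxypropyl)carbamoyl in place of (4-hydroxybutyl)sulfanyl gives an at least 270-fold higher number from compound 2 to compound 3 (2.43 log units; beyond the scatter) in this assay, a large step. Compound 3 has no number here, only a limit: the limit of > 10000 nM in this assay, at which 1 of the 3 values shown sits. The earlier compounds shown here gave no view of a change at this position; now it is clear that a swap between two side chains that both end in a hydroxyl group can carry the read-out from a measured number to that limit.

The change alters the link to the ring and the chain length together, so the step cannot be assigned to either alone. From the compounds shown here alone, how a (3-hydroxypropyl)sulfanyl or a (4-hydroxybutyl)carbamoyl group would read at this carbon remains open, and so does the reading of a (4-hydroxybutyl)amino group.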